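The source may report more compounds than this note shows. Statements on the series, on what has been measured and on what is new or still open speak of the compounds shown alone.

In a functional assay on HeLa cells (Homo sapiens) for cytotoxicity, read by MTT assay, with a stated time of 48 h (on this read-out lower numbers stand for stronger inhibition and higher numbers for weaker inhibition), compound 1 `COc1cc([C@H]2C[C@]2(CO)C(=O)Nc2ccccc2Cl)cc(OC)c1OC` gives 45500 nM. Compound 2 `COc1cc([C@H]2C[C@@]2(CO)C(=O)Nc2ccccc2Cl)cc(OC)c1OC` reaches only a limit of the assay, > 100000 nM. Compound 3 `COc1cc([C@@H]2C[C@@]2(CO)C(=O)Nc2ccccc2Cl)cc(OC)c1OC` departs from compound 2 in one place: the two compounds have the same atoms and bonds and differ only in configuration as drawn: 1 of 2 stereo elements differ; a stereocentre at a saturated ring carbon is drawn R in compound 2 and S in compound 3. Within the data shown here, the one measured step that bears on this is an at least 2.1-fold higher number from compound 1 to compound 2 (0.34 log units; beyond the scatter), and it also rests on (the fact that compounds 1 and 2 differ only in the configuration as drawn). On the strength of that step, a modest shift towards a lower number is expected, though the value may also stay at the limit. The expected change is an at least 1.4-fold lower number from compound 2 to compound 3 (0.15 log units; that floor lies within the scatter). For compound 3 the estimated value is 70000 nM, with an expected range of 25000 nM to 150000 nM.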

Compound 3, half-maximal inhibitory concentration: 13300 nM
Compound 3: middle estimate off by 5.3-fold (0.72 log units), on the high side; measured number outside the range, below it.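

Inverting this one saturated ring carbon stereocentre gives an at least 7.5-fold lower number from compound 2 to compound 3 (0.87 log units; beyond the scatter) in this assay, showing that this centre alone can move the read-out beyond the scatter: the fact that compounds 2 and 3 differ only in the configuration as drawn. Compound 2 stands only at a limit of the assay, > 100000 nM. The mirror-image pair also separates, with a 3.4-fold lower number from compound 1 to compound 3 (0.53 log units; beyond the scatter), and compound 3 carries the lowest number of the three.

On these data alone, whether this preference for compound 3's configuration would persist with an aminomethyl group or a carboxylic acid in place of the hydroxymethyl group remains open. The compounds shown also leave open how the remaining combination of the two stereocentres would read.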